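Moving the Ether Oxygen Along the Ester Side Chain

This account rests on a few compounds, and the source may have more. Where it says the series, first, only, none or still open, it means among the compounds named here.

Compound 1 `CCCc1nc(CC)c(C(=O)OCCCOCc2ccccc2)n1Cc1ccc(-c2ccccc2S(=O)(=O)NC(=O)OCCC(C)C)cc1F`: 2 nM
Compound 2 `CCCOC(=O)NS(=O)(=O)c1ccccc1-c1ccc(Cn2c(CCC)nc(CC)c2C(=O)OCc2ccccc2-c2ccsc2)c(F)c1`: 20 nM

In an assay on isolated protein for binding affinity to Type-2 angiotensin II receptor (Homo sapiens) (on this read-out higher numbers stand for weaker inhibition and lower numbers for stronger inhibition), compound 1 gives the lower of the two numbers; compound 2 lies higher by a gap beyond the scatter. Compound 3 `CCCc1nc(CC)c(C(=O)OCCCCOc2ccccc2)n1Cc1ccc(-c2ccccc2S(=O)(=O)NC(=O)OCCC(C)C)cc1F` carries the same atoms as compound 1, joined differently: phenoxymethyl in place of benzyloxy on a saturated chain carbon, three bonds along the chain from an oxygen next to a carbonyl group. Within the data shown here, no pair of measured compounds isolates such a change, so the size of the step is uncertain. The step from compound 1 to compound 3 is expected to be small, a 1.5-fold higher number from compound 1 to compound 3 (0.18 log units; within the scatter), at or near the scatter, in either direction. Compound 3 is thus estimated at 3 nM, within 1 nM to 12 nM.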

Compound 3, half-maximal inhibitory concentration: 2 nM
The estimate for compound 3 lay 1.5-fold (0.18 log units) above the measured number; the measured number falls inside the stated range.
By their numbers in this assay, from the lowest: compounds 1 and 3 (each within the scatter of the next); then compound 2.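

In this assay, phenoxymethyl in place of benzyloxy gives no change at the digits printed from compound 1 to compound 3 (within the scatter). For this one pair, then, the ether oxygen moves along the ester side chain, with the same atoms kept, without a step beyond the scatter. Nothing available bears on why the number holds. The compounds shown leave open what an amine or a carboxylic acid at this place on the chain would do in this assay. They also leave open whether a longer chain ending in phenoxy would hold the number as well.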